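Heteroaryl Swaps at the Amide Nitrogen Side Chain

A few compounds are considered here, and "the series" means these few. Any claim that something is new, unique, unknown or untested is made for them only; others in the source may bear on it.

Measured compounds in an assay on HEK293 cells for agonist activity at transient receptor potential cation channel subfamily M member 8 (Homo sapiens), read by fluorescence and calcium flux, with a stated time of 15 min; on this read-out higher numbers stand for an effect only at larger amounts of compound and lower numbers for an effect already at smaller amounts:
compound 1, `CCN(Cc1ccc(C)s1)C(=O)COc1ccc(C)cc1`: 178 nM
compound 2, `CCN(Cc1ccco1)C(=O)COc1ccc(C)cc1`: 489 nM
compound 3, `CCN(Cc1cn[nH]c1)C(=O)COc1ccc(C)cc1`: "active" (no number reported), reported without a number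

Compound 3 therefore cannot be placed against compounds 1 and 2 on the numbers; all that is known is that it shows an effect in this assay.

Compound 4, `CCN(Cc1cncs1)C(=O)COc1ccc(C)cc1`, is not yet measured. It differs from compound 3 in one place: 1,3-thiazol-5-yl in place of 1H-pyrazol-4-yl on a saturated chain carbon bound to an amide-type nitrogen.

Within the data shown here, the one measured step that bears on this position is the exchange of one five-membered heteroaryl for another on the same saturated chain carbon bound to an amide-type nitrogen: a 2.7-fold higher number from compound 1 to compound 2 (0.44 log units; beyond the scatter). That step was modest, and the ring carrying sulfur gave the lower number. Since compound 3 has no number, no step size can be stated from compound 3 to compound 4; the expectation rests on compounds 1 and 2 alone. Compound 4 is expected to land near the values of compounds 1 and 2 in this assay, at about 350 nM, with a plausible range of 100 nM to 1200 nM.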

Compound 4, half-maximal effective concentration: 1100 nM
Beside the measured number, compound 4's estimate is 3.1-fold (0.50 log units) below it; the range from low to high includes it.
By their numbers in this assay, from the lowest: compound 1; then compound 2; then compound 4.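

In this assay a ring carrying sulfur no longer goes with the lower number on the saturated chain carbon bound to an amide-type nitrogen: 1,3-thiazol-5-yl gives a 2.2-fold higher number from compound 2 to compound 4 (0.35 log units; beyond the scatter) and a 6.2-fold higher number from compound 1 to compound 4 (0.79 log units; beyond the scatter), so compound 2, with furan-2-yl, falls between the two sulfur-bearing compounds, and compound 4 goes against the trend suggested by compound 1 and compound 2 alone. The step from compound 3 to compound 4 cannot be read, as compound 3 has no number. No measurement at hand accounts for these differences.

On these data alone, what a thiophen-2-yl group without the methyl, or a phenyl ring, would give on this chain carbon remains open. Also open, as far as these compounds go, is whether the order of these rings holds with a propyl chain in place of the ethyl group on the amide nitrogen.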